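Adding a Methyl to the Anilino Ring of Compound 3

A few compounds are considered here, and "the series" means these few. Any claim that something is new, unique, unknown or untested is made for them only; others in the source may bear on it.

Compound 3 `COc1cc(/C=C/C(=O)c2sc(Nc3ccccc3)nc2C)cc(OC)c1OC` carries a plain anilino group on the shared core. In a functional assay on NCI-H460 cells (Homo sapiens) for cytotoxicity, read by MTT assay (a lower number here means a stronger inhibitor, a higher number a weaker inhibitor), compound 3 reaches only the limit of the measurement, > 25000 nM. Compound 1 `COc1cc(/C=C/C(=O)c2sc(Nc3ccc(Cl)c(Cl)c3)nc2C)cc(OC)c1OC`, which carries a 3,4-dichlorophenyl group instead, also reaches only a limit in this assay, > 25000 nM. Among the compounds with values here, compound 2 `COc1cc(/C=C/C(=O)c2sc(Nc3ccc(F)c(Cl)c3)nc2C)cc(OC)c1OC` is the one member of the group with a proper number: in this assay compound 2 gives 6310 nM. Two of the three values thus sit together at the same limit (the limit of > 25000 nM in this assay, at which 2 of the 3 values shown sit), so the step from compound 1 to compound 3 cannot be read, a step that the two limits leave unreadable from compound 1 to compound 3. The readable steps are an at least 3.9-fold lower number from compound 1 to compound 2 (0.59 log units; beyond the scatter) and an at least 3.9-fold higher number from compound 2 to compound 3 (0.59 log units; beyond the scatter).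

Compound 4 `COc1cc(/C=C/C(=O)c2sc(Nc3ccc(C)cc3)nc2C)cc(OC)c1OC` differs from compound 3 by methyl in place of hydrogen on an aromatic carbon, the methyl entering para to a large group. Within the data shown here, no measured step involves a methyl on this ring; the measured changes there only swap or remove halogens. With compound 3 already at the limit, only a sizeable gain could become visible in this assay. The expectation is that compound 4 gives 25000 nM, within a range from 6000 nM to 60000 nM. Put as a step, the expectation reads a number no higher from compound 3 to compound 4 (the limit leaves the size open).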

Compound 4, half-maximal inhibitory concentration: > 25000 nM
Compound 4: a limit, no number; the forecaster's own chance of this, stated with the estimate: 65%; the middle value lies on the limit itself.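

Compound 4 gives > 25000 nM in this assay, which is a limit and not a number. Within the data shown here, compound 2 remains the only one of the four compounds with a proper number, and the one readable new step is an at least 3.9-fold higher number from compound 2 to compound 4 (0.59 log units; beyond the scatter). The steps to compound 4 from compound 3 and from compound 1 cannot be read, so a methyl at this place shows no visible gain, while any smaller effect, in either direction, stays hidden, and three compounds now share one limit: the limit of > 25000 nM in this assay, at which 3 of the 4 values shown sit.

The compounds shown leave open whether another group in place of this methyl, such as a methoxy or an amine, would bring a measurable number in this test of cytotoxicity. Also open, on these data alone, is what a single fluoro or a single chloro on the anilino ring would give, which would help to separate the two halogens of compound 2.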